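The compounds below may be only part of what the source reports. "The series", "measured", "known", "first", "only" and "open" are said of these compounds alone.

Going by the values given here, in a functional assay (strain AB) with Danio rerio as the target, read by microscopy, with a stated time of 1 h (a higher number here means that more compound is needed for the effect, a lower number that less compound is needed), compound 1 `CC(C)(C)C[N+]1(C)CCc2c(sc(NC(=O)Nc3ccc(Cl)cc3)c2C(N)=O)C1` gives 290 nM and compound 2 `C[N+]1(CC2CCCC2)CCc2c(sc(NC(=O)Nc3ccc(Cl)cc3)c2C(N)=O)C1` gives 200 nM on the numbers so far, so the two stand level: the step of a 1.5-fold lower number from compound 1 to compound 2 (0.16 log units; within the scatter) is the only one measured and stays within the scatter. Compound 3 `COCCC[N+]1(C)CCc2c(sc(NC(=O)Nc3ccc(Cl)cc3)c2C(N)=O)C1` differs from compound 2 2-methoxyethyl in place of cyclopentyl on a saturated chain carbon bound to an amine nitrogen in a ring in having 2-methoxyethyl in place of cyclopentyl on a saturated chain carbon bound to an amine nitrogen in a ring. Among the compounds with values here, the one measured step exchanged two carbon-only groups, so it is a weak guide, and no group with oxygen has been measured at this place. A small move towards a higher number in this assay is expected, with a 1.8-fold higher number from compound 2 to compound 3 (0.24 log units; within the scatter) as the estimated step and little beyond the scatter. For compound 3 the expected value is 350 nM with 130 nM to 900 nM as the estimated range.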

Compound 3, half-maximal effective concentration: 480 nM
Beside the measured number, compound 3's estimate is 1.4-fold (0.14 log units) below it; the range from low to high includes it.
By their numbers in this assay, from the lowest: compounds 2, 1 and 3 (each within the scatter of the next, the first and the last beyond it).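

In this assay, a group with oxygen on a saturated chain carbon bound to an amine nitrogen in a ring produces a step beyond the scatter, a 2.4-fold higher number from compound 2 to compound 3 (0.38 log units; beyond the scatter) when 2-methoxyethyl replaces cyclopentyl. Set against tert-butyl, the same group gives a 1.7-fold higher number from compound 1 to compound 3 (0.22 log units; within the scatter) so the size of the change depends on the group it replaces. No measurement here bears on why the number moves. Going by these compounds, whether the oxygen or the lost ring goes with the step stays open, as does the effect of an amine or a carboxylic acid on this chain.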